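A few compounds are considered here, and "the series" means these few. Any claim that something is new, unique, unknown or untested is made for them only; others in the source may bear on it.

Working notes on the series. Compound 1 `CCc1nc(N)c2nc(O)n(Cc3ccccc3)c2n1` carries the shared core with a benzyl group on the ring nitrogen, a hydroxyl on the five-membered ring carbon and an ethyl chain on the six-membered ring. Among the compounds with values here, in a functional assay (spleen, spleen) for activation, with Mus musculus as the target (a higher number here means that more compound is needed for the effect, a lower number that less compound is needed), compound 1 gives 1 uM, which is the only actual number among the three measured compounds. Compound 2 `Nc1ncnc2c1nc(O)n2C1CCCC1` replaces the benzyl group with a cyclopentyl ring and drops the ethyl chain. In this assay compound 2 reaches only the limit of > 10 uM. Compound 3 `Nc1ncnc2c1nc(I)n2Cc1ccccc1` keeps the benzyl group but carries an iodine instead of the hydroxyl and again no ethyl chain. In this assay compound 3 likewise reports only the limit of > 10 uM. The pattern of the measured set is therefore (the limit of > 10 uM in this assay, at which 2 of the 3 values shown sit), so compound 1 is the one anchor from which the next step is read.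

Compound 4 `CCCc1nc(N)c2nc(O)n(Cc3ccccc3)c2n1` differs from compound 1 by methyl in place of hydrogen on a saturated chain carbon, two bonds along the chain from an aromatic carbon, that is, the ethyl chain of compound 1 becomes a propyl chain. Within the data shown here, no measured pair shows this exact step, so no step size is known. The expected step from compound 1 to compound 4 is a 2.0-fold lower number from compound 1 to compound 4 (0.30 log units; within the scatter), a small gain in potency that may still fall inside the usual scatter. Compound 4 is estimated at 0.5 uM in this assay, with a range of 0.15 uM to 2 uM.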

Compound 4, minimum effective concentration: 1 uM
Compound 4: the middle estimate sits 2.0-fold (0.30 log units) below what was measured; the measured number falls inside the stated range.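

In this assay the change from ethyl to propyl gives no change at the digits printed from compound 1 to compound 4 (within the scatter). Within the data shown here, this is the first readable step: until now there was a single actual number, and the compounds sitting at a limit differ from compound 1 in more than one place, so none of them could say anything about the chain on its own. It shows that, on a saturated chain carbon, two bonds along the chain from an aromatic carbon, methyl in place of hydrogen leaves the read-out as an actual number that stays within the scatter, so this position accepts the ethyl to propyl change without a visible cost in this assay.

One step on one chain does not show whether a butyl chain, a longer chain or a branched isopropyl group at the same place would keep the read-out, nor whether an amine or a carboxylic acid on the chain would be accepted. Wider comparison in the series also remains thin, since actual numbers come only from compound 1 and compound 4: the limit of > 10 uM in this assay, at which 2 of the 4 values shown sit.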